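A few compounds are considered here, and "the series" means these few. Any claim that something is new, unique, unknown or untested is made for them only; others in the source may bear on it.

Compound 1 `O=C1C(Nc2ccc(I)cc2)=CC(=O)c2c1nc1n2[C@H]2OC[C@@H](O)[C@H]2OC1` gives 2150 nM in a functional assay on MGC-803 cells (Homo sapiens) for inhibition, read by sulforhodamine B assay; a lower number here means a stronger inhibitor, a higher number a weaker inhibitor. Compound 2 `O=C1C(NC2CCCC2)=CC(=O)c2c1nc1n2[C@H]2OC[C@@H](O)[C@H]2OC1` reaches only a limit of the assay in this assay, namely > 16000 nM. Compound 3 `O=C1C(NC2CC2)=CC(=O)c2c1nc1n2[C@H]2OC[C@@H](O)[C@H]2OC1` likewise reaches only a limit of the assay in this assay, > 4000 nM. Among the values shown, compound 3 therefore stands as a limit and not as a number, one of two such results. The step of an at least 7.4-fold higher number from compound 1 to compound 2 (0.87 log units; beyond the scatter) lies beyond the scatter, whereas the step of an at least 1.8-fold higher number from compound 1 to compound 3 (0.26 log units; that floor lies within the scatter) has a floor that lies within the scatter. The step that the two limits leave unreadable from compound 2 to compound 3 cannot be sized because the limit of > 16000 nM in this assay, at which 1 of the 3 values shown sits, and the limit of > 4000 nM in this assay, at which 1 of the 3 values shown sits, fix both of its ends.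

Compound 4 `O=C1C(Nc2cccc(F)c2)=CC(=O)c2c1nc1n2[C@H]2OC[C@@H](O)[C@H]2OC1` differs from compound 3 in one place: 3-fluorophenyl in place of cyclopropyl on an amine nitrogen. The measured step that bears on this is the one running the other way, where a 4-iodophenyl on the amine nitrogen gave a number and cyclopropyl gave only a limit, as an at least 1.8-fold higher number from compound 1 to compound 3 (0.26 log units; that floor lies within the scatter) shows; it was at most modest in size. A return to an aryl group on the amine nitrogen is therefore expected to lower the number, and the step of an at least 1.3-fold lower number from compound 3 to compound 4 (0.12 log units; that floor lies within the scatter) is estimated to be modest. Compound 4 is expected to give 3000 nM, within a range from 1000 nM to 10000 nM.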

Compound 4, half-maximal inhibitory concentration: 1470 nM
The estimate for compound 4 lay 2.0-fold (0.31 log units) above the measured number, within the range that was stated.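

With compound 4, a second aryl group on the amine nitrogen gives a measured number in this assay, and it now stands clear of both cycloalkyl groups, with an at least 2.7-fold lower number from compound 3 to compound 4 (0.43 log units; beyond the scatter) and an at least 10-fold lower number from compound 2 to compound 4 (1.03 log units; beyond the scatter). The 3-fluorophenyl and 4-iodophenyl groups do not separate, with a 1.5-fold lower number from compound 1 to compound 4 (0.17 log units; within the scatter), so these two differently substituted aryl groups cannot be told apart at this position in this assay, and compound 4 makes the contrast with cyclopropyl readable where the floor of the step from compound 1 alone lay within the scatter. The step from the cyclopropyl compound remains a floor and not a size, because compound 3 stands only at a limit of the assay: the limit of > 4000 nM in this assay, at which 1 of the 4 values shown sits.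

On these data alone, how far compound 2 really lies from the aryl compounds stays open, because compound 2 also stands only at a limit of the assay: the limit of > 16000 nM in this assay, at which 1 of the 4 values shown sits. It also remains open whether an unsubstituted phenyl, or a phenyl carrying a methoxy or a carboxylic acid, would stay level with compound 1 and compound 4, or whether a benzyl on the amine nitrogen would keep the gain over the cycloalkyl groups.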